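The source may hold more compounds than are shown below. What is called first, only, known or untested is meant among the compounds shown, and "the series" means these compounds.

Working notes on the series. In a functional assay for inhibition, with Homo sapiens as the target (a higher number here means a weaker inhibitor, a lower number a stronger inhibitor), compound 2 `C=CCSc1nncc2cnc(C)n12` gives 61000 nM. Compound 1 `C=CCSc1nncc2cnc(CCC)n12` returns only a limit in this assay, > 48000 nM. The change between the two is ethyl in place of hydrogen on a saturated chain carbon bound to an aromatic carbon, and the measured step is a step that the limit leaves unreadable from compound 2 to compound 1. Compound 3 `Cc1ncn2c(S)nncc12` also returns only a limit in this assay, > 48000 nM. The difference between the core of compound 3 and the core of compound 2 is not broken down here. Compound 4 `CCCc1ncn2c(S)nncc12` carries the same change as the measured pair, (ethyl in place of hydrogen on a saturated chain carbon bound to an aromatic carbon). Since the limit of > 48000 nM in this assay, at which 2 of the 3 values shown sit, the earlier step gives no readable size, and compound 3 itself starts at that limit, so the expected step in this assay is a step that the limit leaves unreadable from compound 3 to compound 4. Compound 4 is expected at 60000 nM, between 30000 nM and 150000 nM, most likely again reported only as a limit.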

Compound 4, half-maximal inhibitory concentration: > 48000 nM
Compound 4: a limit, no number (the forecaster's own chance of this, stated with the estimate: 80%); the middle value is on the limit's open side.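

Among the compounds shown here, compound 3 and compound 4 both return only a limit in this assay, so no step between them can be read. The compounds shown leave open what size of effect, if any, methyl to propyl has on the core of compound 3.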